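The source may report more compounds than this note shows. Statements on the series, on what has been measured and on what is new or still open speak of the compounds shown alone.

Measured so far in a functional assay on MCF7 cells (Homo sapiens) for antiproliferative activity, read by MTT assay, with a stated time of 72 h; a lower number here means a stronger inhibitor, a higher number a weaker inhibitor:
compound 1 `CC(=O)O[C@H]1CC[C@]2(C)[C@H](CC[C@@](C)(O)[C@H]2CC[C@@H]2C(C)=CC[C@H]3[C@H](CC[C@]3(C)OC(C)=O)C2(C)C)OC1(C)C` gives 39200 nM
compound 3 `CC1=CC[C@H]2[C@H](CC[C@]2(C)O)C(C)(C)[C@@H]1CC[C@H]1[C@]2(C)CC/C(=N/OC(=O)c3ccccc3)C(C)(C)O[C@H]2CC[C@@]1(C)O` gives 25600 nM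
compound 2 `CC1=CC[C@H]2[C@H](CC[C@]2(C)O)C(C)(C)[C@@H]1CC[C@H]1[C@]2(C)CC[C@H](OC(=O)CCC(=O)O)C(C)(C)O[C@H]2CC[C@@]1(C)O` reaches only a limit of the assay, > 50000 nM

Compound 2 thus stands at the weak end of the numbers shown (the limit of > 50000 nM in this assay, at which 1 of the 3 values shown sits), with no measured figure of its own, while compound 1 and compound 3 each give a number inside the assay window. Compound 4 `CC1=CC[C@H]2[C@H](CC[C@]2(C)O)C(C)(C)[C@@H]1CC[C@H]1[C@]2(C)CC[C@H](OC(=O)c3ccc(Cl)c(Cl)c3)C(C)(C)O[C@H]2CC[C@@]1(C)O` is compound 2 with 3,4-dichlorophenyl in place of 2-carboxyethyl on a carbonyl carbon. No measured step runs between any two of these compounds, so the size of the change from compound 2 to compound 4 cannot be read off; the expectation is a step toward stronger inhibition in this assay, an at least 1.6-fold lower number from compound 2 to compound 4 (0.22 log units; that floor lies within the scatter), somewhat beyond the scatter. Compound 4 is estimated at 30000 nM, expected between 12000 nM and 80000 nM.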

Compound 4, half-maximal inhibitory concentration: 11900 nM
For compound 4 the middle estimate is 2.5-fold (0.40 log units) above the measured one; measured number outside the range, below it.
By their numbers in this assay, from the lowest: compound 4; then compounds 3 and 1 (each within the scatter of the next). At a limit, above all of these: compound 2.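

In this assay, 3,4-dichlorophenyl in place of 2-carboxyethyl on a carbonyl carbon gives an at least 4.2-fold lower number from compound 2 to compound 4 (0.62 log units; beyond the scatter). This position therefore affects the read-out, and with the 3,4-dichlorophenyl group compound 4 has a measured number inside the assay window. The true size of the step remains unknown because compound 2 sits at a limit of the assay: the limit of > 50000 nM in this assay, at which 1 of the 4 values shown sits.

The shown pair cannot separate the contribution of the chlorines, the aromatic ring and the loss of 2-carboxyethyl. An unsubstituted phenyl or a longer alkyl chain on the same carbonyl carbon would begin to separate them.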